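This account rests on a few compounds, and the source may have more. Where it says the series, first, only, none or still open, it means among the compounds named here.

The measured compounds:
Compound 1, `O=C(NCc1ccc(NC(=O)c2cccc(F)c2N2CCCC2)cc1)OCc1cccnc1` — > 100000 nM
Compound 2, `O=C(NCc1ccc(NC(=O)c2cc(F)ccc2N2CCCC2)cc1)OCc1cccnc1` — 44800 nM
Compound 3, `O=C(NCc1ccc(NC(=O)c2cc(-c3ccccc3)ccc2N2CCCC2)cc1)OCc1cccnc1` — > 100000 nM

All three were tested in a functional assay on SGC-7901 cells (Homo sapiens) for inhibition, read by MTT assay, with a stated time of 72 h; on this read-out lower numbers stand for stronger inhibition and higher numbers for weaker inhibition. Compound 1 reaches only the limit of this assay, > 100000 nM, and not a number. Compound 3 likewise stops at the limit, > 100000 nM. Compound 2 alone yields a number in this assay, 44800 nM. Going by the values given here, the one step that can be sized, an at least 2.2-fold higher number from compound 2 to compound 3 (0.34 log units; beyond the scatter), runs toward the ceiling described by the limit of > 100000 nM in this assay, at which 2 of the 3 values shown sit, so compound 2 is the only measured compound that falls inside the range this assay can resolve.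

Compound 4, `Cc1cccc(C(=O)Nc2ccc(CNC(=O)OCc3cccnc3)cc2)c1N1CCCC1`, differs from compound 1 in one place: methyl in place of fluoro on an aromatic carbon. Among the compounds with values here, no measured step exchanges a methyl for a fluoro, and the step from compound 2 to compound 3 concerns a phenyl for a fluoro, another kind of exchange. Compound 1 sits at the limit, so any step from it can be seen only if compound 4 moves down into the measurable range. With nothing in the measured steps pointing that way, compound 4 is expected to stay at or near the limit, an estimate of 100000 nM with a range of 40000 nM to 300000 nM. That expectation amounts to an estimated step of a number no higher from compound 1 to compound 4 (the limit leaves the size open), which is no step beyond the scatter.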

Compound 4, half-maximal inhibitory concentration: > 100000 nM
Compound 4 was reported as a limit (the forecaster's own chance of this, stated with the estimate: 60%); the middle value lies on the limit itself.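

In this assay compound 4 gives > 100000 nM, which is a limit and not a number. Compound 1 likewise gives a limit, so no step can be read between compound 1 and compound 4: the limit of > 100000 nM in this assay, at which 3 of the 4 values shown sit. The compounds shown leave open whether methyl and fluoro at this place differ at all in this assay.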